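Methoxy Added to the Benzyl Arm of Compound 2

The source may report more compounds than this note shows. Statements on the series, on what has been measured and on what is new or still open speak of the compounds shown alone.

Compound 1 `CC[C@@H]1CC2(C[C@@H](CC)N1)C(=O)NC(=O)N2Cc1ccccc1`: > 100 uM
Compound 2 `COC(=O)C1=C(O)C[C@H](c2ccccn2)N(Cc2ccccc2)[C@@H]1c1ccccn1`: 33.2 uM
Compound 3 `COC(=O)C1C(=O)C(C(=O)OC)[C@H](c2cccc([N+](=O)[O-])c2)N(Cc2ccc(OC)cc2)[C@@H]1c1cccc([N+](=O)[O-])c1`: > 100 uM

Among the measured compounds shown here, in an ADME assay on J774.1 cells (Mus musculus) for cytotoxicity, with a stated time of 48 h (a higher number here means that more compound is needed for the effect, a lower number that less compound is needed), compound 2 gives 33.2 uM, the only plain number among the three. Compound 1 reaches only a limit of the assay, > 100 uM. Compound 3 likewise gives only a limit, > 100 uM. Compound 2 therefore stands alone with a measured value, while the two other results are the limit of > 100 uM in this assay, at which 2 of the 3 values shown sit.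

Compound 4 `COC(=O)C1=C(O)C[C@H](c2ccccn2)N(Cc2cccc(OC)c2)[C@@H]1c1ccccn1` has not yet been measured in this assay. It differs from compound 2 in one place: methoxy in place of hydrogen on an aromatic carbon. For the measured compounds named here, no step between measured compounds covers this change. The step from compound 2 to compound 4 is expected to stay within the usual scatter, a 1.1-fold higher number from compound 2 to compound 4 (0.02 log units; within the scatter). Compound 4 is thus expected to give 35 uM, estimated between 15 uM and 80 uM.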

Compound 4, concentration for half-maximal effect: > 100 uM
Compound 4: no number, only a limit; the forecaster's own chance of this, stated with the estimate: 20%; middle value at least 2.8-fold (0.45 log units) away from the limit.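

Replacing benzyl with 3-methoxybenzyl gives an at least 3.0-fold higher number from compound 2 to compound 4 (0.47 log units; beyond the scatter) in this assay. This is the first step shown for the benzyl arm, and it shows that a single methoxy on this aromatic carbon, meta to a large group, is enough to move the result beyond the scatter. Compound 4 gives only a limit, so the step has no known upper end: the limit of > 100 uM in this assay, at which 3 of the 4 values shown sit.

Going by these compounds, it remains open whether a smaller group such as fluorine or a larger one such as ethoxy would give a similar step here. On these data alone, the effect of an amine or a carboxylic acid at this place is also open.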